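A few compounds are considered here, and "the series" means these few. Any claim that something is new, unique, unknown or untested is made for them only; others in the source may bear on it.

Measured compounds:
compound 1, `Cc1cc2[nH]nc(N)c2c(=O)[nH]1`, with 8%
compound 2, `Nc1n[nH]c2cc(-c3cccs3)[nH]c(=O)c12`, with 12%

Both numbers come from an assay on isolated protein for inhibition of MAP kinase-activated protein kinase 5 (Homo sapiens), read by mobility shift assay, tested at 30 uM; on this read-out higher numbers stand for more inhibition at the one concentration tested (going by the name of the read-out) and lower numbers for less inhibition. Compound 2 has the upper of the two numbers, yet its nearest neighbour is compound 1, and the step of a number 4 percentage points higher from compound 1 to compound 2 (within the scatter) lies within the scatter, so the two compounds cannot be told apart on this assay.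

Compound 3, `CC(C)(C)c1cc2[nH]nc(N)c2c(=O)[nH]1`, has not been measured. It differs from compound 2 as follows: tert-butyl in place of thiophen-2-yl on an aromatic carbon. Going by the values given here, the only measured step at this position is the exchange of methyl for thiophen-2-yl, which gave a number 4 percentage points higher from compound 1 to compound 2 (within the scatter), a change within the scatter. Since neither a small nor a ring-bearing group shifted the number at this position beyond the scatter, the step of a number 3 percentage points lower from compound 2 to compound 3 (within the scatter) is expected to stay within the scatter as well. Compound 3 is therefore estimated at 9%, within a range from 0% to 22%.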

Compound 3, a percentage reported as inhibition, at one concentration (the size of the read-out at that concentration, not a potency): 1%
The estimate for compound 3 lay 8 percentage points above the measured number, within the range that was stated.
By their numbers in this assay, from the lowest: compounds 3, 1 and 2 (each within the scatter of the next, the first and the last beyond it).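

Going by these compounds alone, the step of a number 11 percentage points lower from compound 2 to compound 3 (beyond the scatter) in this assay is the first change at this position to go beyond the scatter, so the group on this aromatic carbon can move the number, if only modestly. The step of a number 7 percentage points lower from compound 1 to compound 3 (within the scatter) stays within the scatter, so tert-butyl and methyl cannot be told apart here, and only thiophen-2-yl and tert-butyl separate, with the methyl compound within the scatter of both. Nothing measured here explains why these two groups differ.

With thiophen-2-yl the only ring-bearing group shown, it remains open whether the separation comes with aromatic rings in general, as a phenyl group would test. Also open, going by these compounds, is how an amine, a carboxylic acid or a longer chain at this position would read.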